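Working notes: cytotoxicity across one amide-substituent change

This account rests on a few compounds, and the source may have more. Where it says the series, first, only, none or still open, it means among the compounds named here.

Measured compounds and their values:
compound 1 `O=C(CSc1c[nH]c2cccc(Br)c12)N(Cc1ccccc1)Cc1ccccc1`: 25700 nM
compound 2 `O=C(CSc1c[nH]c2c(Br)cccc12)NCc1ccc(Cl)c(Cl)c1`: > 100000 nM
compound 3 `COc1ccccc1CNC(=O)CSc1cn(C)c2ccccc12`: > 100000 nM

In an ADME assay on HEK-293T cells (Homo sapiens) for cytotoxicity, read by CCK-8 assay, with a stated time of 24 h (a higher number here means that more compound is tolerated, a lower number that less compound is tolerated), compound 1 gives 25700 nM, the only numerical result among the three measured compounds. Compound 2 sits at > 100000 nM, which is a limit of the assay and not a number. Compound 3 also sits at > 100000 nM, again a limit rather than a number. Taken together, the limit of > 100000 nM in this assay, at which 2 of the 3 values shown sit, describes where two of the three values stand. No two measured compounds differ in a single place, so no measured step can be drawn from these three, and no cause for any difference among them can be read from the data shown.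

Compound 4 `CN(Cc1ccccc1)C(=O)CSc1c[nH]c2cccc(Br)c12` is not yet measured. It differs from compound 1 in one place: hydrogen in place of phenyl on a saturated chain carbon bound to an amide-type nitrogen. With no measured step of this kind in the series, the size of the step from compound 1 to compound 4 is expected to be modest, a 1.8-fold higher number from compound 1 to compound 4 (0.24 log units; within the scatter), leaning toward more compound being tolerated, but not clearly beyond the usual scatter. Compound 4 is therefore estimated at 45000 nM, with an expected range from 15000 nM to 100000 nM, and a fair chance that the assay reports only a limit for compound 4.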

Compound 4, half-maximal cytotoxic concentration: 25100 nM
Beside the measured number, compound 4's estimate is 1.8-fold (0.25 log units) above it; low and high end bracket the measured number.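

In this assay, going by these compounds alone, the first readable step is flat: hydrogen in place of phenyl on a saturated chain carbon bound to an amide-type nitrogen, which also reads as benzyl to methyl, gives a 1.0-fold lower number from compound 1 to compound 4 (0.01 log units; within the scatter) and so stays within the scatter. Compound 1 and compound 4 therefore stand level, and the phenyl that leaves does not set the tolerated concentration in this pair. Nothing measured here gives a cause for this outcome.

Within the data shown here, whether the benzyl group that remains on the amide nitrogen in both compounds matters stays open, as no step touches it. Also open, as far as these compounds go, is whether an amine or a carboxylic acid at the end of a longer chain, in place of the methyl of compound 4, would move the number beyond the scatter.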